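From 4-fluorophenyl to 3-chlorophenyl on a shared core

This account rests on a few compounds, and the source may have more. Where it says the series, first, only, none or still open, it means among the compounds named here.

Compound 1 `COc1ccccc1Oc1c(N)nc(-c2cccc(C)c2)nc1OCCO`: 1380 nM
Compound 2 `COc1ccccc1Oc1c(N)nc(-c2ccc(F)cc2)nc1OCCO`: 15900 nM

In a functional assay on A-375 cells (Homo sapiens) for cytotoxicity, read by CCK-8 assay, with a stated time of 24 h (a higher number here means a weaker inhibitor, a lower number a stronger inhibitor), compound 2 has the higher, and so weaker, of the two values at 15900 nM. Compound 3 `COc1ccccc1Oc1c(N)nc(-c2cccc(Cl)c2)nc1OCCO` carries 3-chlorophenyl in place of 4-fluorophenyl on an aromatic carbon. Within the data shown here, one measured step bears on this change: a 12-fold higher number from compound 1 to compound 2 (1.06 log units; beyond the scatter). Among the measured compounds shown here, it also removes or installs 4-fluorophenyl, but its partner is 3-methylphenyl, and no measured compound carries 3-chlorophenyl. Leaving 4-fluorophenyl is therefore expected to give a large drop in this assay, though this is uncertain. The expected change is a 6.4-fold lower number from compound 2 to compound 3 (0.80 log units; beyond the scatter). For compound 3 the estimated value is 2500 nM, with an expected range of 700 nM to 9000 nM.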

Compound 3, half-maximal inhibitory concentration: 30200 nM
Beside the measured number, compound 3's estimate is 12-fold (1.08 log units) below it; the whole stated range lies below it.
By their numbers in this assay, from the lowest: compound 1; then compounds 2 and 3 (each within the scatter of the next).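

In this assay, 3-chlorophenyl in place of 4-fluorophenyl gives a 1.9-fold higher number from compound 2 to compound 3 (0.28 log units; within the scatter), so this change separates neither compound from the other. Chloro in place of methyl gives a 22-fold higher number from compound 1 to compound 3 (1.34 log units; beyond the scatter), so the lower number of compound 1 does not extend to every phenyl group with a single added atom or small group at this position. Nothing measured here accounts for that contrast. Still open, going by these compounds, is whether a methoxy group, an amine or a carboxylic acid on this phenyl ring would give a number closer to that of compound 1.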